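Extending the Acyl Group at the Amine End

The source may hold more compounds than are shown below. What is called first, only, known or untested is meant among the compounds shown, and "the series" means these compounds.

Among the measured compounds shown here, compound 3 `CC(C)CCNC(=O)[C@H](C)NC(=O)C[C@H](O)[C@H](CC(C)C)NC(=O)[C@@H](NC(=O)C(C)C)C(C)C` gives 1.6 nM in an assay on isolated protein for inhibition of Pepsin A (Sus scrofa) (a lower number here means a stronger inhibitor, a higher number a weaker inhibitor), the lowest of the three numbers measured so far. Compound 1 `CC(C)CCNC(=O)[C@H](C)NC(=O)C[C@H](O)[C@H](CC(C)C)NC(=O)[C@@H](NCC(=O)C(C)(C)C)C(C)C` gives 7.5 nM and compound 2 `CC(C)CCNC(=O)[C@H](C)NC(=O)C[C@H](O)[C@H](CC(C)C)NC(=O)[C@@H](NC(=O)OC(C)C)C(C)C` gives 8.6 nM; the steps of a 4.7-fold lower number from compound 1 to compound 3 (0.67 log units; beyond the scatter) and a 5.4-fold lower number from compound 2 to compound 3 (0.73 log units; beyond the scatter) show that exchanging the group on this amine nitrogen moves the number only modestly. Compound 4 `CCC(C)C(=O)N[C@H](C(=O)N[C@@H](CC(C)C)[C@@H](O)CC(=O)N[C@@H](C)C(=O)NCCC(C)C)C(C)C` carries methyl in place of hydrogen on a saturated chain carbon, two bonds along the chain from a carbonyl carbon, so that isopropylcarbonyl becomes (sec-butyl)carbonyl. For the measured compounds named here, no measured pair tests a single added methyl of this kind; those two steps swapped larger pieces and still stayed modest. A step of a 1.3-fold higher number from compound 3 to compound 4 (0.10 log units; within the scatter) is therefore expected, small and possibly inside the scatter. Compound 4 is estimated at 2 nM, with a range from 0.7 nM to 6 nM.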

Compound 4, inhibition constant: 0.31 nM
Compound 4: middle estimate off by 6.5-fold (0.81 log units), on the high side; the measured number lies below the stated range.
By their numbers in this assay, from the lowest: compound 4; then compound 3; then compounds 1 and 2 (each within the scatter of the next).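

A single added methyl, which turns isopropylcarbonyl into (sec-butyl)carbonyl, gives a 5.2-fold lower number from compound 3 to compound 4 (0.71 log units; beyond the scatter) and so moves the number about as far as the earlier exchanges of larger groups on this amine nitrogen. Against the two other groups, (sec-butyl)carbonyl gives a 28-fold lower number from compound 2 to compound 4 (1.44 log units; beyond the scatter) and a 24-fold lower number from compound 1 to compound 4 (1.38 log units; beyond the scatter), both large steps, which leaves compound 4 with the lowest number of the four. Nothing available explains why one methyl matters this much. On these data alone, whether a longer chain such as n-pentyl or a cyclohexyl ring on this carbonyl carbon would lower the number further remains open.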